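Swapping the chlorophenyl end for a pyridine

The source may report more compounds than this note shows. Statements on the series, on what has been measured and on what is new or still open speak of the compounds shown alone.

The compounds share a core in which an amide ring carries a substituent on its nitrogen and a triple bond leads to an aromatic ring. Compound 1 `CC(C)N1CCc2nc(C#Cc3cccnc3)ccc2C1=O` carries an isopropyl group on the nitrogen and, in a functional assay on HEK293 cells for positive allosteric modulation of metabotropic glutamate receptor 5 (Homo sapiens), read by FLIPR and calcium flux (on this read-out lower numbers stand for an effect already at smaller amounts and higher numbers for an effect only at larger amounts of compound), compound 1 was reported as "not active" (no number reported). Compound 2 `O=C1c2ccc(C#Cc3cccnc3)nc2CCN1C1CCCC1` carries a cyclopentyl group, and in this assay compound 2 gives 748 nM. Compound 3 `O=C1c2ccc(C#Cc3cccc(Cl)c3)nc2CCN1C1CCCCC1` carries a cyclohexyl group and a 3-chlorophenyl ring, and in this assay compound 3 gives 171 nM, the lowest of the two numbers, with compound 2 beyond the scatter above it.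

Compound 4 `O=C1c2ccc(C#Cc3cccnc3)nc2CCN1C1CCCCC1` differs from compound 3 by pyridin-3-yl in place of 3-chlorophenyl on a triple-bonded carbon. Compound 2, which also carries the pyridin-3-yl ring, gives 748 nM, and compound 1 with the same ring gives "not active" (no number reported). The step from compound 3 to compound 4 is therefore expected to move upward, by about a 2.6-fold higher number from compound 3 to compound 4 (0.42 log units; beyond the scatter). Compound 4 is expected to give roughly 450 nM, within a range from 150 nM to 1500 nM.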

Compound 4, half-maximal effective concentration: 387 nM
Beside the measured number, compound 4's estimate is 1.2-fold (0.07 log units) above it; the measured number falls inside the stated range.
By their numbers in this assay, from the lowest: compound 3; then compounds 4 and 2 (each within the scatter of the next).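

With the cyclohexyl group held fixed, this pair isolates the ring at the end of the triple bond: in this assay, pyridin-3-yl in place of 3-chlorophenyl gives a 2.3-fold higher number from compound 3 to compound 4 (0.35 log units; beyond the scatter) as a modest step. With the pyridin-3-yl ring held fixed, cyclohexyl in place of cyclopentyl on the amide-type nitrogen gives a 1.9-fold lower number from compound 2 to compound 4 (0.29 log units; within the scatter) and so does not separate these two groups in this read-out. Nothing available explains the effect of the ring swap on the number.

The compounds shown leave open how a plain phenyl ring or a thiophene ring at the end of the triple bond would compare with these two rings. They also leave open how a benzyl group on the nitrogen would compare with cyclohexyl and cyclopentyl.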